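Swapping the aryl ether for an aryl thioether

A few compounds are considered here, and "the series" means these few. Any claim that something is new, unique, unknown or untested is made for them only; others in the source may bear on it.

Measured compounds:
compound 1 `Nc1cc(N)c2nc(-c3ccccc3)c(Oc3ccc(F)cc3)nc2c1`: 87100 nM
compound 2 `COc1cc(CNc2nc3cc(N)cc(N)c3nc2-c2ccccc2)cc(OC)c1OC`: 20000 nM
compound 3 `CCOC(=O)[C@H](CCC(=O)O)NC(=O)c1ccc(Oc2nc3cc(N)cc(N)c3nc2-c2ccccc2)cc1`: 20000 nM

Of the compounds shown here, three built on a shared core have been tested in a functional assay on DU-145 cells (Homo sapiens) for inhibition, read by sulforhodamine B assay, with a stated time of 48 h; a lower number here means a stronger inhibitor of growth, a higher number a weaker inhibitor of growth. Compound 1 gives 87100 nM, the highest of the three numbers and so the weakest growth inhibition in this set. Compound 2 gives 20000 nM, and compound 3 gives 20000 nM; each of these sits below compound 1 by a gap that is beyond the scatter, and the two gaps are of the same size.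

The next compound, compound 4 `COc1ccc(Sc2nc3cc(N)cc(N)c3nc2-c2ccccc2)cc1`, differs from compound 1 in a single place: (4-methoxyphenyl)sulfanyl in place of 4-fluorophenoxy on an aromatic carbon. Among the compounds with values here, no step between two measured compounds that differ in one place is available, so the size of this change has to be judged from the spread of the set alone. The other two measured compounds both read lower than compound 1, which suggests that the core tolerates different groups at this carbon while staying in a narrow window. Compound 4 is therefore expected to land at 40000 nM, with a range from 10000 nM to 120000 nM. That corresponds to an expected step of a 2.2-fold lower number from compound 1 to compound 4 (0.34 log units; beyond the scatter), a modest move toward stronger inhibition that could still fall within the scatter of repeated measurements.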

Compound 4, concentration for total growth inhibition: 33100 nM
For compound 4 the middle estimate is 1.2-fold (0.08 log units) above the measured one; low and high end bracket the measured number.
By their numbers in this assay, from the lowest: compounds 2, 3 and 4 (each within the scatter of the next); then compound 1.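

In this assay, within the data shown here, the exchange of 4-fluorophenoxy for (4-methoxyphenyl)sulfanyl on the aromatic carbon next to the ring nitrogen gives a 2.6-fold lower number from compound 1 to compound 4 (0.42 log units; beyond the scatter), the first direct evidence that a change at this one place moves the number by more than the scatter. The step is modest and runs toward stronger growth inhibition, so the 4-fluorophenoxy group of compound 1 is not the better of these two groups in this assay, and this carbon accepts an aryl group joined through sulfur as well as one joined through oxygen. Nothing available explains why the number moves.

The compounds shown leave open how much of the step belongs to the sulfur that joins the ring to the core and how much to the methoxy group that replaces fluorine, as both changes arrive together in compound 4. A 4-methoxyphenoxy or a (4-fluorophenyl)sulfanyl group at this carbon would separate the two, and an aryl ring carrying a chlorine or a hydroxyl group in place of the methoxy would show how far the ring substituent alone matters.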